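The source may report more compounds than this note shows. Statements on the series, on what has been measured and on what is new or still open speak of the compounds shown alone.

Among the measured compounds shown here, compound 2 `CNC(=O)c1ccc(Oc2cccc(NC(=S)Nc3ccc(F)c(F)c3)c2)nc1` gives 69300 nM in a functional assay on MDA-MB-231 cells (Homo sapiens) for antiproliferative activity, read by MTT assay (on this read-out lower numbers stand for stronger inhibition and higher numbers for weaker inhibition), the highest of the three numbers measured so far. Compound 1 `CNC(=O)c1ccc(Oc2cccc(NC(=S)Nc3ccc(Cl)cc3Cl)c2)nc1` gives 20700 nM and compound 3 `CNC(=O)c1ccc(Oc2cccc(NC(=S)Nc3ccc(F)c(Cl)c3)c2)nc1` gives 28600 nM in this assay. Compound 4 `CNC(=O)c1ccc(Oc2cccc(NC(=S)Nc3ccc(Cl)cc3)c2)nc1` differs from compound 2 by 4-chlorophenyl in place of 3,4-difluorophenyl on an amide-type nitrogen. For the measured compounds named here, two measured steps bear on this change: a 2.4-fold lower number from compound 2 to compound 3 (0.38 log units; beyond the scatter), and a 3.3-fold higher number from compound 1 to compound 2 (0.52 log units; beyond the scatter), which together show that chlorine-bearing rings on this nitrogen have so far given lower numbers than the 3,4-difluorophenyl of compound 2. Compound 4 carries a single chlorine and no fluorine, so a modest lowering is expected, roughly a 2.0-fold lower number from compound 2 to compound 4 (0.30 log units; within the scatter). The expected value for compound 4 in this assay is therefore 35000 nM, with a likely range from 15000 nM to 80000 nM.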

Compound 4, half-maximal inhibitory concentration: 66500 nM
Compound 4: middle estimate off by 1.9-fold (0.28 log units), on the low side; low and high end bracket the measured number.
By their numbers in this assay, from the lowest: compounds 1 and 3 (each within the scatter of the next); then compounds 4 and 2 (each within the scatter of the next).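

In this assay, a single chlorine on the ring at this nitrogen does not by itself give a lower number: 4-chlorophenyl and 3,4-difluorophenyl cannot be told apart (a 1.0-fold lower number from compound 2 to compound 4 (0.02 log units; within the scatter)). The steps (a 2.3-fold higher number from compound 3 to compound 4 (0.37 log units; beyond the scatter)) and (a 3.2-fold higher number from compound 1 to compound 4 (0.51 log units; beyond the scatter)) tie the lower numbers of compound 3 and compound 1 to rings bearing chlorine plus a second halogen, a pattern that compound 2, with two fluorines, goes against. Nothing given here explains this. From the compounds shown here alone, how an unsubstituted phenyl, a methoxy group or a trifluoromethyl group on this ring would read remains open.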